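Ring heteroatoms on the ketone in a long-chain fatty acyl series

A few compounds are considered here, and "the series" means these few. Any claim that something is new, unique, unknown or untested is made for them only; others in the source may bear on it.

Measured so far:
compound 1, `CCCCCCCC/C=C\CCCCCCC(=O)c1ccccn1`, > 100000 nM
compound 2, `CCCCCCCC/C=C\CCCCCCC(=O)c1ccccc1`, > 100000 nM

In an assay on isolated protein for inhibition of Fatty-acid amide hydrolase 1 (Homo sapiens) (a higher number here means a weaker inhibitor, a lower number a stronger inhibitor), compound 1 gives only a limit, > 100000 nM. In this assay compound 2 likewise gives only a limit, > 100000 nM. The step that the two limits leave unreadable from compound 1 to compound 2 is therefore not readable; both values sit at the limit of > 100000 nM in this assay, at which 2 of the 2 values shown sit. Compound 2 thus stands at the limit of this assay, with no number to place it against.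

Compound 3, `CCCCCCCC/C=C\CCCCCCC(=O)c1ccncn1`, carries the change (pyrimidin-4-yl in place of phenyl on a carbonyl carbon). Within the data shown here, the one measured step, from compound 1 to compound 2, also exchanged a six-membered aromatic ring on the carbonyl carbon, and its size could not be read. Among the measured compounds shown here, no measured step therefore tells the direction or size of the step from compound 2 to compound 3. The expectation is that this assay again reports a limit, so the step that the limit leaves unreadable from compound 2 to compound 3 is expected to be small. For compound 3 the estimated inhibition constant is 200000 nM, with a range from 50000 nM to 1000000 nM.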

Compound 3, inhibition constant: 110 nM
Compound 3: middle estimate off by 1800-fold (3.26 log units), on the high side; measured number outside the range, below it.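

In this assay, the ring on the carbonyl carbon decides whether a readable number appears at all, with pyrimidin-4-yl in place of phenyl giving an at least 900-fold lower number from compound 2 to compound 3 (2.95 log units; beyond the scatter) and pyrimidin-4-yl in place of pyridin-2-yl giving an at least 900-fold lower number from compound 1 to compound 3 (2.95 log units; beyond the scatter). A ring hetero atom alone is therefore not sufficient, as compound 1 with pyridin-2-yl remains at a limit, as does compound 2 with phenyl: the limit of > 100000 nM in this assay, at which 2 of the 3 values shown sit. The step between these two limit compounds cannot be read, so the series gives no ranking of pyridin-2-yl against phenyl.

The compounds shown do not separate the contributions of the two ring nitrogens of pyrimidin-4-yl, a question that pyridin-4-yl or pyrimidin-2-yl on the same carbonyl carbon would address. Also open, going by these compounds, is whether the gain persists with a shorter chain or a fully saturated chain.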